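Chloro in place of methoxy: working notes

The compounds below may be only part of what the source reports. "The series", "measured", "known", "first", "only" and "open" are said of these compounds alone.

Measured in an ADME assay on HUVEC cells (Homo sapiens) for cytotoxicity, read by MTT assay, with a stated time of 24 h; on this read-out higher numbers stand for lower toxicity in this test and lower numbers for higher toxicity in this test:
compound 1 `Cc1ccc(/C=C/c2nnc(-c3ccc4c(c3)OCCO4)o2)cc1`: 265000 nM
compound 2 `COc1ccc(/C=C/c2nnc(-c3ccc4c(c3)OCCO4)o2)cc1`: 312000 nM

Within the data shown here, compound 2, at 312000 nM, stands within the scatter of compound 1, the only other measured compound. Compound 3 `Clc1ccc(/C=C/c2nnc(-c3ccc4c(c3)OCCO4)o2)cc1` carries chloro in place of methoxy on an aromatic carbon, para to a large group: chloro in place of methoxy on an aromatic carbon. Among the measured compounds shown here, the single measured step at this place, a 1.2-fold higher number from compound 1 to compound 2 (0.07 log units; within the scatter), is small, and no chloro compound has a measured value. No change beyond the scatter is therefore expected in this assay, in either direction. The estimated step is a 1.2-fold lower number from compound 2 to compound 3 (0.08 log units; within the scatter). The expected value of compound 3 is 260000 nM, with an estimated range of 140000 nM to 430000 nM.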

Compound 3, half-maximal cytotoxic concentration: 312000 nM
The estimate for compound 3 lay 1.2-fold (0.08 log units) below the measured number; the range from low to high includes it.
By their numbers in this assay, from the lowest: compounds 1, 2 and 3 (each within the scatter of the next).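

In this assay the change from 4-methoxyphenyl to 4-chlorophenyl leaves the number in place (no change at the digits printed from compound 2 to compound 3 (within the scatter)), and chloro in place of methyl stays equally close (a 1.2-fold higher number from compound 1 to compound 3 (0.07 log units; within the scatter)). On this aromatic carbon, para to a large group, methyl, methoxy and chloro are therefore not told apart by this read-out. No supporting measurement is available to explain this.

As far as these compounds go, whether an amine or a carboxylic acid at this position would give a step beyond the scatter remains open. So does the effect of changes elsewhere on the shared core.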